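The compounds below may be only part of what the source reports. "The series", "measured", "known", "first", "only" and "open" are said of these compounds alone.

Working notes on the series. The single read-out here is an ADME assay on MDBK cells (Bos taurus) for cytotoxicity, read by MTT assay, with a stated time of 96 h; on this read-out lower numbers stand for higher toxicity in this test and higher numbers for lower toxicity in this test. Compound 1 `COc1ccc(-c2nc3cc(C(C)=O)ccc3[nH]2)c(OC)c1` gives 73000 nM in this assay. Compound 2 `COc1ccc(-c2nc3cc(/C(C)=N/NC(N)=O)ccc3[nH]2)c(OC)c1` carries, in place of the acetyl of compound 1, the group counted in a group of 7 heavy atoms (3 carbon, 3 nitrogen, 1 oxygen; no ring) in place of a group of 3 heavy atoms (2 carbon, 1 oxygen; no ring), on an aromatic carbon. In this assay compound 2 gives only the limit > 100000 nM. The step of an at least 1.3-fold higher number from compound 1 to compound 2 (0.13 log units; that floor lies within the scatter) is therefore itself only a floor, and it rests on (the limit of > 100000 nM in this assay, at which 2 of the 3 values shown sit).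

Compound 3 `CC(=O)c1ccc2c(c1)nc(-c1ccccc1)n2C1CCCCC1` has a different core from compound 1; how the two cores differ is not broken down here. In this assay compound 3 gives only the limit > 100000 nM.

Compound 4 `C/C(=N\NC(N)=O)c1ccc2c(c1)nc(-c1ccccc1)n2C1CCCCC1` is not yet measured in this assay. It stands to compound 3 as compound 2 stands to compound 1: the change is a group of 7 heavy atoms (3 carbon, 3 nitrogen, 1 oxygen; no ring) in place of a group of 3 heavy atoms (2 carbon, 1 oxygen; no ring), on an aromatic carbon, and the surroundings of the place are described in the same words as for the change from compound 1 to compound 2, so this is the same change carried onto the core of compound 3. Among the compounds with values here, the one measured instance of it, from compound 1 to compound 2, gave only a floor that lies within the scatter, so no shift in either direction is established by it. Compound 3 already sits at the limit described in the limit of > 100000 nM in this assay, at which 2 of the 3 values shown sit.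

For compound 4 the step that the limit leaves unreadable from compound 3 to compound 4 is expected to be small. Compound 4 is expected to come out around 150000 nM in this assay, most likely as a limit again, with a range from 60000 nM to 400000 nM.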

Compound 4, half-maximal cytotoxic concentration: > 100000 nM
Compound 4: no number, only a limit; the forecaster's own chance of this, stated with the estimate: 85%; the middle value does not contradict the limit.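

In this assay compound 3 and compound 4 both give only a limit, so no step can be read between them, and the change from acetyl to the entering group has no readable size on this core: the limit of > 100000 nM in this assay, at which 3 of the 4 values shown sit.

From the compounds shown here alone, whether that change shifts this read-out in either direction, on either core, stays open, as do the actual values of the compounds that sit at the limit.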